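The source may hold more compounds than are shown below. What is called first, only, known or untested is meant among the compounds shown, and "the series" means these compounds.

Compound 1, `C/C(=C\c1cc(-c2cccnc2)co1)C(N)=O`, gives 13200 nM in a functional assay on MCF7 cells (Homo sapiens) for cytotoxicity, read by CCK-8 assay, with a stated time of 24 h; on this read-out lower numbers stand for stronger inhibition and higher numbers for weaker inhibition. Compound 2, `C/C(=C\c1cc(-c2ccc(C)nc2)co1)C(N)=O`, gives 10200 nM.

Of the two numbers, that of compound 2 is the smaller, yet the step of a 1.3-fold lower number from compound 1 to compound 2 (0.11 log units; within the scatter) lies within the scatter, so the two compounds cannot be told apart on these data. Compound 3, `C/C(=C\c1cc(-c2ccc(F)nc2)co1)C(N)=O`, differs from compound 2 by fluoro in place of methyl on an aromatic carbon. Among the measured compounds shown here, the only measured step at this position is a 1.3-fold lower number from compound 1 to compound 2 (0.11 log units; within the scatter), which stayed within the scatter, so no step beyond the scatter is expected in this assay; the expected step is a 1.1-fold higher number from compound 2 to compound 3 (0.03 log units; within the scatter). Compound 3 is therefore estimated at 11000 nM, with a range from 5000 nM to 25000 nM.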

Compound 3, half-maximal inhibitory concentration: 14100 nM
Beside the measured number, compound 3's estimate is 1.3-fold (0.11 log units) below it; measured number inside the range.
By their numbers in this assay, from the lowest: compounds 2, 1 and 3 (each within the scatter of the next).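

In this assay this position, on an aromatic carbon next to the ring nitrogen, now carries hydrogen, methyl or fluoro, and the steps of a 1.4-fold higher number from compound 2 to compound 3 (0.14 log units; within the scatter) and a 1.1-fold higher number from compound 1 to compound 3 (0.03 log units; within the scatter) both lie within the scatter. Fluoro therefore cannot be told apart from either methyl or hydrogen here, so none of the three groups separates from the others at this place. No evidence bearing on this result is available. Going by these compounds, whether an amine, a carboxylic acid or a longer chain at this place would give a step beyond the scatter remains open.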